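This account rests on a few compounds, and the source may have more. Where it says the series, first, only, none or still open, it means among the compounds named here.

Measured compounds:
compound 1, `O=C(CC(c1ccccc1)C(C(=O)Nc1ccccn1)C(=O)Nc1ccccn1)c1ccccc1`: 28100 nM
compound 2, `O=C(CC(c1ccc(Cl)cc1)C(C(=O)Nc1ccccn1)C(=O)Nc1ccccn1)c1ccccc1`: 13600 nM

In a functional assay on HeLa cells (Homo sapiens) for inhibition, read by MTT assay, with a stated time of 48 h (a higher number here means a weaker inhibitor, a lower number a stronger inhibitor), compound 1 gives 28100 nM and compound 2 gives 13600 nM. Among the measured compounds shown here, compound 2 stands at the lowest of the two numbers, and its only neighbour is compound 1, which is reached by reversing the step of a 2.1-fold lower number from compound 1 to compound 2 (0.32 log units; beyond the scatter) that put chloro in place of hydrogen on an aromatic carbon.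

Compound 3, `O=C(CC(c1ccc(F)cc1)C(C(=O)Nc1ccccn1)C(=O)Nc1ccccn1)c1ccccc1`, has not yet been measured in this assay. It differs from compound 2 in one place: fluoro in place of chloro on an aromatic carbon

For the measured compounds named here, only one measured step bears on this change, the modest one from compound 1 to compound 2, a 2.1-fold lower number from compound 1 to compound 2 (0.32 log units; beyond the scatter), in which chloro entered where hydrogen had been. Going from chloro to fluoro undoes part of that change without returning all the way to hydrogen, so the number for compound 3 is expected to sit between those of compound 2 and compound 1, most likely closer to compound 2 and within the scatter of it. The step from compound 2 to compound 3 is therefore estimated as a 1.4-fold higher number from compound 2 to compound 3 (0.15 log units; within the scatter), a slight rise. Compound 3 is expected to give about 19000 nM in this assay, with a range from 10000 nM to 38000 nM.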

Compound 3, half-maximal inhibitory concentration: 20800 nM
Beside the measured number, compound 3's estimate is 1.1-fold (0.04 log units) below it, and the stated range covers the measured number.
By their numbers in this assay, from the lowest: compounds 2, 3 and 1 (each within the scatter of the next, the first and the last beyond it).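

In this assay the change from chloro to fluoro on this aromatic carbon gives a 1.5-fold higher number from compound 2 to compound 3 (0.18 log units; within the scatter) and the fluoro compound set against the unsubstituted one gives a 1.4-fold lower number from compound 1 to compound 3 (0.13 log units; within the scatter) so compound 3 cannot be told apart from either of its two neighbours. This is new, since the earlier pair offered only one separation at this position, between hydrogen and chloro, and the fluoro compound now falls inside that gap without siding with either end. Exchanging one halogen for the other at this place therefore moves the number by no more than repeated measurements of the same compound might, and only chloro stands clearly apart from hydrogen, by a modest margin. Nothing available here explains this pattern or links it to any measured property of these groups.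

Still open, on these data alone, is whether a different group on this same aromatic carbon, such as methoxy, an amine or a carboxylic acid, would shift the number well beyond this narrow band. Also open, as far as these compounds go, is whether chloro and fluoro would behave in the same way elsewhere on the shared core.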